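The compounds below may be only part of what the source reports. "The series", "measured", "known", "first", "only" and "open" are said of these compounds alone.

Measured so far in a functional assay on MCF7 cells (Homo sapiens) for cytotoxicity, read by sulforhodamine B assay, with a stated time of 72 h; a higher number here means a weaker inhibitor, a lower number a stronger inhibitor:
- compound 1 `CC(=O)OC[C@H]1O[C@H](OC2=CC(=O)c3ccccc3C2=O)[C@H](OC(C)=O)[C@@H](OC(C)=O)[C@H]1OC(C)=O`: 4580 nM
- compound 2 `CC(=O)OC[C@H]1O[C@@H](OC2=CC(=O)c3ccccc3C2=O)[C@H](OC(C)=O)[C@@H](OC(C)=O)[C@@H]1OC(C)=O`: 4760 nM
- compound 3 `O=C1C=C(OCc2cn([C@@H]3O[C@H](CO)[C@@H](O)[C@H](O)[C@H]3O)nn2)C(=O)c2ccccc21`: 38900 nM

Compound 3 stands highest of the three numbers in this assay; its nearest neighbour is compound 2, whose number is far lower, beyond the scatter, and compound 1 lies slightly further off again. Compound 4 `O=C1C=C(OCc2cn([C@@H]3O[C@H](CO)[C@H](O)[C@H](O)[C@H]3O)nn2)C(=O)c2ccccc21` is unmeasured. It differs from compound 3 in configuration only: the two compounds have the same atoms and bonds and differ only in configuration as drawn: 1 of 5 stereo elements differ; a stereocentre at a saturated ring carbon is drawn S in compound 3 and R in compound 4.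

Within the data shown here, one measured step bears on this change. Compound 1 and compound 2 also share all atoms and bonds and differ only in how two stereocentres are drawn, and a 1.0-fold higher number from compound 1 to compound 2 (0.02 log units; within the scatter). That comparison rests on the fact that compounds 1 and 2 differ only in the configuration as drawn and shows no shift beyond the scatter for a configurational change of this type in this assay.

On that basis the change from compound 3 to compound 4 is expected to give no step beyond the scatter in this assay, the expected step being a 1.0-fold lower number from compound 3 to compound 4 (0.01 log units; within the scatter). Compound 4 is therefore estimated at 38000 nM, with a range from 15000 nM to 95000 nM.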

Compound 4, half-maximal inhibitory concentration: > 50000 nM
Compound 4 was reported as a limit; the forecaster's own chance of this, stated with the estimate: 5%; at least 1.3-fold (0.11 log units) between middle value and limit.
By their numbers in this assay, from the lowest: compounds 1 and 2 (each within the scatter of the next); then compound 3. At a limit, above all of these: compound 4.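

Compound 4 is reported only as a limit (> 50000 nM) in this assay. The change of one stereocentre at a saturated ring carbon can therefore be read only as a floor (an at least 1.2-fold higher number from compound 3 to compound 4 (0.10 log units; that floor lies within the scatter)), which neither establishes a real shift nor excludes one. This pair adds a single-centre change in compounds carrying free hydroxyl groups, whereas the earlier step (a 1.0-fold higher number from compound 1 to compound 2 (0.02 log units; within the scatter)) covered two centres in acetylated compounds, and a floor does not allow the two steps to be ranked.

On these data alone, the true number for compound 4 stays open, as does the outcome of this same single-centre change with acetyl esters on the hydroxyl groups. Also open, as far as these compounds go, is how an amine or a carboxylic acid in place of the hydroxyl group at this stereocentre would read in this assay.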